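Compound 1 to compound 4: one more chloro

The source may hold more compounds than are shown below. What is called first, only, known or untested is meant among the compounds shown, and "the series" means these compounds.

Measured in an ADME assay on HEK293 cells (Homo sapiens) for cytotoxicity, read by MTT assay, with a stated time of 48 h (on this read-out lower numbers stand for stronger inhibition and higher numbers for weaker inhibition), as follows:
- compound 1 `COc1ccc(-c2nc(C)c(C(=O)CSc3nc(-c4ccc(Cl)cc4)c(C#N)c(=O)[nH]3)s2)cc1` gives 63000 nM
- compound 2 `Cc1nc(-c2ccccc2)sc1C(=O)CSc1nc(-c2ccccc2)c(C#N)c(=O)[nH]1` gives 93500 nM
- compound 3 `COc1ccc(-c2nc(SCC(=O)c3sc(-c4ccc(Cl)cc4)nc3C)[nH]c(=O)c2C#N)cc1OC` gives "not determined" (no result reported)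

Compound 1 sits within the scatter of compound 2, and compound 3 offers no number for comparison. Compound 4 `COc1ccc(-c2nc(C)c(C(=O)CSc3nc(-c4ccc(Cl)c(Cl)c4)c(C#N)c(=O)[nH]3)s2)cc1` is compound 1 with chloro in place of hydrogen on an aromatic carbon, ortho to a chloro group and meta to a large group, taking 4-chlorophenyl to 3,4-dichlorophenyl, counted as chloro in place of hydrogen on an aromatic carbon in all. For the measured compounds named here, no single-place step between measured compounds is available in this assay to size this change. No step beyond the scatter is therefore expected, with a slight lean to lower numbers. The estimated move is a 1.3-fold lower number from compound 1 to compound 4 (0.12 log units; within the scatter) and stays within the scatter. Compound 4 is expected at 48000 nM within an estimated range of 20000 nM to 110000 nM on this reasoning.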

Compound 4, half-maximal inhibitory concentration: 45600 nM
Compound 4: the middle estimate sits 1.1-fold (0.02 log units) above what was measured; low and high end bracket the measured number.
By their numbers in this assay, from the lowest: compounds 4, 1 and 2 (each within the scatter of the next, the first and the last beyond it).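

In this assay the series now has its first single-place step, which reads a 1.4-fold lower number from compound 1 to compound 4 (0.14 log units; within the scatter). Taking 4-chlorophenyl to 3,4-dichlorophenyl, with the new chloro ortho to a chloro group and meta to a large group, therefore gives no step beyond the scatter on this read-out. No supporting data bear on this result.

On these data alone, whether an amine or a carboxylic acid on the same aromatic carbon would give a step beyond the scatter stays open. So does whether chloro at this place behaves alike on other members of the series.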